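A few compounds are considered here, and "the series" means these few. Any claim that something is new, unique, unknown or untested is made for them only; others in the source may bear on it.

Measured in a functional assay on MDA-MB-468 cells (Homo sapiens) for antiproliferative activity, read by MTT assay, with a stated time of 72 h (on this read-out higher numbers stand for weaker inhibition and lower numbers for stronger inhibition), so far:
- compound 1 (`COc1cc(-c2nccn2C(C)C)cc(OC)c1OC`): > 100000 nM (a limit)
- compound 2 (`COc1cc(-c2nccn2Cc2ccccc2)cc(OC)c1OC`): > 100000 nM (a limit)
- compound 3 (`COc1cc(-c2nccn2-c2ccc(C)cc2)cc(OC)c1OC`): 400 nM (a number)

Going by the values given here, compound 3 gives the only number so far. The other two entries reflect the limit of > 100000 nM in this assay, at which 2 of the 3 values shown sit, and give no number.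

Compound 4 (`COc1cc(-c2nccn2-c2ccc(F)cc2)cc(OC)c1OC`) has fluoro in place of methyl on an aromatic carbon, para to a large group. Among the compounds with values here, two measured steps bear on this only indirectly: an at least 250-fold lower number from compound 1 to compound 3 (2.39 log units; beyond the scatter) and an at least 250-fold lower number from compound 2 to compound 3 (2.39 log units; beyond the scatter) are both large, but both change the group on the aromatic nitrogen. Within the data shown here, no measured step changes the methyl of the 4-methylphenyl group. Compound 4 keeps a substituted phenyl on that nitrogen, so it is expected to stay close to compound 3 at 400 nM. The expected change is a 1.5-fold higher number from compound 3 to compound 4 (0.18 log units; within the scatter) and nothing beyond the scatter is expected in either direction. Compound 4 is estimated at 600 nM with an expected range from 150 nM to 2500 nM as working bounds.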

Compound 4, half-maximal inhibitory concentration: 62200 nM
Compound 4: the middle estimate sits 100-fold (2.02 log units) below what was measured, and the stated range ends below it.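

In this assay, the aromatic carbon para to a large group proves highly sensitive: a change of one heavy atom, fluoro in place of methyl, gives a 160-fold higher number from compound 3 to compound 4 (2.19 log units; beyond the scatter). A substituted phenyl on the aromatic nitrogen is therefore not sufficient on its own, since 4-fluorophenyl in place of benzyl gives only an at least 1.6-fold lower number from compound 2 to compound 4 (0.20 log units; that floor lies within the scatter), and 4-fluorophenyl in place of isopropyl gives only an at least 1.6-fold lower number from compound 1 to compound 4 (0.20 log units; that floor lies within the scatter). These two steps are floors, and their true size stays unknown, because compound 1 and compound 2 each sit at a limit rather than a number: the limit of > 100000 nM in this assay, at which 2 of the 4 values shown sit.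

Open, from the compounds shown here alone, is whether the number seen with methyl depends on methyl itself or would hold with ethyl, chloro or methoxy at this place. Also open, going by these compounds, is how an amine or a longer chain there would read.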